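This account rests on a few compounds, and the source may have more. Where it says the series, first, only, none or still open, it means among the compounds named here.

In a functional assay on A549 cells (Homo sapiens) for inhibition, read by MTT assay, with a stated time of 24 h (a lower number here means a stronger inhibitor, a higher number a weaker inhibitor), compound 1 (`CC1(C)[C@H]2CC[C@]1(C)N(Cc1cn(-c3ccc(F)cc3)nn1)C(=O)C2`) gives 230 nM and compound 2 (`CC1(C)[C@H]2CC[C@]1(C)N(Cc1cn(-c3ccccc3Cl)nn1)C(=O)C2`) gives 70 nM as the lowest of the two numbers. Compound 3 (`CC1(C)[C@H]2CC[C@]1(C)N(Cc1cn(-c3ccccc3)nn1)C(=O)C2`) has yet to be measured. It differs from compound 2 by hydrogen in place of chloro on an aromatic carbon in a single place, with hydrogen in place of chloro on an aromatic carbon, ortho to a large group, so that 2-chlorophenyl becomes phenyl. Among the measured compounds shown here, only one measured step bears on this change, a 3.3-fold lower number from compound 1 to compound 2 (0.52 log units; beyond the scatter) with 2-chlorophenyl in place of 4-fluorophenyl on an aromatic nitrogen. That step exchanges two substituents at once, so it does not isolate the chloro group. On the strength of a 3.3-fold lower number from compound 1 to compound 2 (0.52 log units; beyond the scatter) alone, compound 3 is expected to give a modestly higher number than compound 2. The estimated change is a 2.3-fold higher number from compound 2 to compound 3 (0.36 log units; beyond the scatter) in this assay as a rise of modest size. The estimate for compound 3 is 160 nM (expected range 70 nM to 350 nM).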

Compound 3, half-maximal inhibitory concentration: 70 nM
Estimate against measurement, compound 3: 2.3-fold (0.36 log units) above; low and high end bracket the measured number.
By their numbers in this assay, from the lowest: compounds 2 and 3 (each within the scatter of the next); then compound 1.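

In this assay, taking the chloro group off the ring gives no change at the digits printed from compound 2 to compound 3 (within the scatter), so the 2-chlorophenyl of compound 2 and the phenyl of compound 3 cannot be told apart and the chloro group at this place, ortho to a large group, is not needed for the low number. The other new step, a 3.3-fold lower number from compound 1 to compound 3 (0.52 log units; beyond the scatter), is a change in one place, and it shows that the gap seen earlier between the 4-fluorophenyl of compound 1 and the 2-chlorophenyl of compound 2 goes with the fluoro group and not with the chloro group. No measurement is at hand that explains either result.

The compounds shown leave open whether a methoxy group or an amine at the chloro position would read like chloro and hydrogen. They also leave open whether a methyl group in place of the fluoro group of compound 1 would give a number like that of compound 1 or that of compound 3.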